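Aryl-urea quinazoline series: tert-butyl for methoxy, second core

The compounds below may be only part of what the source reports. "The series", "measured", "known", "first", "only" and "open" are said of these compounds alone.

Compound 1 `COc1ccc(NC(=O)Nc2cccc(CNc3ncnc4ccccc34)c2)cc1` is the reference of the series. In a functional assay on MGC-803 cells (Homo sapiens) for antiproliferative activity, read by MTT assay (on this read-out higher numbers stand for weaker inhibition and lower numbers for stronger inhibition), compound 1 gives 27300 nM. Compound 2 `CC(C)(C)c1ccc(NC(=O)Nc2cccc(CNc3ncnc4ccccc34)c2)cc1` differs from it by tert-butyl in place of methoxy on an aromatic carbon and in this assay compound 2 gives 7470 nM; the step is a 3.7-fold lower number from compound 1 to compound 2 (0.56 log units; beyond the scatter). Compound 3 `COc1ccc(NC(=O)Nc2cccc(CNc3ncnc4cc(OC)c(OC)cc34)c2)cc1` carries a second core, and the difference between the two cores is not broken down here. In this assay compound 3 gives 12300 nM; against compound 2 this lies within the scatter, against compound 1 it is beyond it.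

Compound 4 `COc1cc2ncnc(NCc3cccc(NC(=O)Nc4ccc(C(C)(C)C)cc4)c3)c2cc1OC` is not yet measured. It differs from compound 3 by tert-butyl in place of methoxy on an aromatic carbon, the same change as from compound 1 to compound 2, at the same place. For compound 4 the step is expected to be a 3.5-fold lower number from compound 3 to compound 4 (0.55 log units; beyond the scatter), set beside the earlier step and resting on the fact that compound 3 (12300 nM) stands close to compound 2 while compound 1 (27300 nM) is the weaker partner of the earlier pair. In this assay compound 4 is therefore estimated at 3500 nM, expected to fall between 1500 nM and 9000 nM.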

Compound 4, half-maximal inhibitory concentration: 6790 nM
Compound 4: the middle estimate sits 1.9-fold (0.29 log units) below what was measured; the range from low to high includes it.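

On the core of compound 3, tert-butyl in place of methoxy gives in this assay a 1.8-fold lower number from compound 3 to compound 4 (0.26 log units; within the scatter), and this step cannot be told apart from the one on the core of compound 1: the same change on two cores in this assay, a 3.7-fold lower number (0.56 log units; beyond the scatter) from compound 1 to compound 2 and a 1.8-fold lower number (0.26 log units; within the scatter) from compound 3 to compound 4, 2.0-fold (0.30 log units) apart, within the scatter of two such steps. The change can thus be carried between these two cores without a detectable difference in step size, but on the core of compound 3 the step alone does not stand clear of the scatter. Two pairs in one assay give no rule for further cores, and they do not show why each step has its size.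

Open, as far as these compounds go, is whether other groups at the same place, on an aromatic carbon para to a large group, such as trifluoromethyl, chlorine or a carboxylic acid, would give matching steps on both cores. Also open, from the compounds shown here alone, is how an amine or a longer alkoxy chain in place of the methoxy groups on the core of compound 3 would read in this assay.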